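A Fluoro-for-Methoxy Exchange Carried to a Second Pair

The source may hold more compounds than are shown below. What is called first, only, known or untested is meant among the compounds shown, and "the series" means these compounds.

The study covers four compounds sharing a core. Compound 1 `COc1ccc(CSc2nnc(-c3cc(OC)c(OC)c(OC)c3)n2-c2ccc(OC)cc2)cc1` was tested in a functional assay on HepG2 cells (Homo sapiens) for inhibition, read by MTT assay, with a stated time of 48 h (a lower number here means a stronger inhibitor, a higher number a weaker inhibitor), where compound 1 gives 41100 nM. Compound 2 `COc1ccc(-n2c(SCc3ccc(F)cc3)nnc2-c2cc(OC)c(OC)c(OC)c2)cc1` differs from compound 1 by fluoro in place of methoxy on an aromatic carbon, and in this assay compound 2 gives 35000 nM. The step of a 1.2-fold lower number from compound 1 to compound 2 (0.07 log units; within the scatter) is therefore small and within the scatter of repeated measurements.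

Compound 3 `COc1ccc(C(=O)CSc2nnc(-c3cc(OC)c(OC)c(OC)c3)n2-c2ccc(N(C)C)cc2)cc1` carries a different arrangement around the core; the difference between the core of compound 3 and the core of compound 1 is not broken down here. In this assay compound 3 gives 18800 nM, the lowest of the three numbers, though its distance from compound 2 lies within the scatter and only its distance from compound 1 lies beyond it.

Compound 4 `COc1cc(-c2nnc(SCC(=O)c3ccc(F)cc3)n2-c2ccc(N(C)C)cc2)cc(OC)c1OC` has not yet been measured. It differs from compound 3 by fluoro in place of methoxy on an aromatic carbon, the same change that turns compound 1 into compound 2, made at a place described in the same words. Because the earlier step of a 1.2-fold lower number from compound 1 to compound 2 (0.07 log units; within the scatter) was small, the expected step from compound 3 to compound 4 is likewise small, a 1.2-fold lower number from compound 3 to compound 4 (0.07 log units; within the scatter), resting on that single precedent. Compound 4 is thus estimated at 16000 nM in this assay, with a likely range from 8000 nM to 35000 nM.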

Compound 4, half-maximal inhibitory concentration: > 60000 nM
Compound 4: no number, only a limit (the forecaster's own chance of this, stated with the estimate: 10%); middle value at least 3.7-fold (0.57 log units) away from the limit.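

In this assay compound 4 gives > 60000 nM, which is a limit of the assay and not a number, so the step of an at least 3.1-fold higher number from compound 3 to compound 4 (0.50 log units; beyond the scatter) has a known lower bound but no known size. The exchange of 4-methoxyphenyl for 4-fluorophenyl therefore did not behave alike on the two cores, since it was within the scatter on one and beyond it on the other: the same change on two cores in this assay, a 1.2-fold lower number (0.07 log units; within the scatter) from compound 1 to compound 2 and an at least 3.1-fold higher number (0.50 log units; beyond the scatter) from compound 3 to compound 4, at least 3.7-fold (0.57 log units) apart, beyond the scatter of two such steps. This comparison rests on a single pair for each core and shows that the outcome of the change depends on its surroundings, but it does not show which feature of the core of compound 3 is responsible, how weak compound 4 really is, or what would happen on a third core.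

The compounds shown leave open whether another group in the same place on the core of compound 3, such as chloro, trifluoromethyl or a nitrile, would stay close to the methoxy compound or would also reach the limit of the assay. They also leave open whether a hydroxy group or an amine there would give a measurable number, which could show how far the loss seen with fluoro extends.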